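A few compounds are considered here, and "the series" means these few. Any claim that something is new, unique, unknown or untested is made for them only; others in the source may bear on it.

Measured compounds:
compound 1 `Cc1ccc(C#Cc2cn(C/C=C\CN3C(=O)c4ccccc4C3=O)c(=O)[nH]c2=O)cc1` — 238000 nM
compound 2 `O=C1c2ccccc2C(=O)N1C/C=C\Cn1cc(C#Cc2ccc(Br)cc2)c(=O)[nH]c1=O` — 80000 nM
compound 3 `CCCCCCCCC#Cc1cn(C/C=C/CN2C(=O)c3ccccc3C2=O)c(=O)[nH]c1=O` — > 250000 nM

In a functional assay on CCRF-CEM cells (Homo sapiens) for antiproliferative activity, read by MTT assay, with a stated time of 3 days (on this read-out lower numbers stand for stronger inhibition and higher numbers for weaker inhibition), compound 3 stands only at a limit of the assay, (the limit of > 250000 nM in this assay, at which 1 of the 3 values shown sits), with no number of its own. Compound 4 `CCCCCc1ccc(C#Cc2cn(C/C=C/CN3C(=O)c4ccccc4C3=O)c(=O)[nH]c2=O)cc1` differs from it by 4-pentylphenyl in place of octyl on a triple-bonded carbon. Within the data shown here, no measured step covers this alkyl-to-aryl exchange; the only measured step, a 3.0-fold lower number from compound 1 to compound 2 (0.47 log units; beyond the scatter), changes a substituent on an aryl ring already present and so bears on it only indirectly. Compound 1 and compound 2, both aryl-bearing, gave numbers within this assay, whereas compound 3 with octyl gave only a limit. Compound 4 is therefore expected to fall within the measurable range, at an estimated 130000 nM (range 40000 nM to 400000 nM), which would mean an estimated step of an at least 1.9-fold lower number from compound 3 to compound 4 (0.28 log units; that floor lies within the scatter).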

Compound 4, half-maximal inhibitory concentration: 23000 nM
Estimate against measurement, compound 4: 5.7-fold (0.75 log units) above; measured number below the stated range.
By their numbers in this assay, from the lowest: compound 4; then compound 2; then compound 1. At a limit, above all of these: compound 3.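

On a triple-bonded carbon, 4-pentylphenyl and octyl are not equivalent in this assay: the exchange gives an at least 10-fold lower number from compound 3 to compound 4 (1.03 log units; beyond the scatter), a large step at a position where the earlier step covered only a substituent on an aryl ring. The size of this step is only a floor, since compound 3 sits at a limit: the limit of > 250000 nM in this assay, at which 1 of the 4 values shown sits.

From the compounds shown here alone, whether the ring alone or the ring with its pentyl chain carries the gain stays open. Also open, going by these compounds, is how an amine, a carboxylic acid or a longer chain in place of pentyl would read here.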